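The source may hold more compounds than are shown below. What is called first, only, known or untested is meant among the compounds shown, and "the series" means these compounds.

Compound 1, `COc1ccc(/C=N/Nc2nc(C)c[se]2)cc1`, and compound 2, `COc1ccc(/C=N/Nc2nc(-c3ccccc3)c[se]2)cc1`, share the same core and differ in a single place. In a functional assay on DU-145 cells (Homo sapiens) for cytotoxicity, read by XTT assay, with a stated time of 72 h (on this read-out higher numbers stand for weaker inhibition and lower numbers for stronger inhibition), compound 1 gives > 84900 nM, which is a limit of the assay and not a number. In this assay compound 2 gives 50900 nM. The step of an at least 1.6-fold lower number from compound 1 to compound 2 (0.22 log units; that floor lies within the scatter) puts phenyl in place of methyl on an aromatic carbon, and its floor rests on (the limit of > 84900 nM in this assay, at which 1 of the 2 values shown sits). Compound 3, `COc1ccc(/C=N/N(C(C)=O)c2nc(C)c[se]2)cc1`, differs from compound 1 by acetyl in place of hydrogen on a nitrogen on an aromatic ring. Within the data shown here, the one measured step touches the aromatic carbon and not the nitrogen, so no measured step bears directly on this change; what the two measured values show is that both compounds sit at the weak end of this assay, with compound 1 at a limit. Among the measured compounds shown here, with no step at this nitrogen to draw on, the expectation for compound 3 is that the change brings no shift beyond the scatter, a step of an at least 1.1-fold lower number from compound 1 to compound 3 (0.05 log units; that floor lies within the scatter). Compound 3 is therefore estimated at 75000 nM, with a range from 20000 nM to 250000 nM, and a real chance that this assay again reports only a limit.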

Compound 3, half-maximal inhibitory concentration: > 74300 nM
Compound 3: no number, only a limit; the forecaster's own chance of this, stated with the estimate: 55%; the middle value is on the limit's open side.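

In this assay compound 3 gives > 74300 nM, which is a limit of the assay and not a number. Among these compounds, compound 1 also stands at a limit, so no step from compound 1 to compound 3 can be read. The compounds shown leave open whether acetyl in place of hydrogen on this nitrogen changes the read-out in this assay at all.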